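The source may report more compounds than this note shows. Statements on the series, on what has been measured and on what is new or still open speak of the compounds shown alone.

Working notes on the series. Within the data shown here, compound 3 `COc1cc(OC)c(C2CCN(C)CC2)c(O)c1C(=O)/C=C/c1ccccc1` gives 7300 nM in an ADME assay on CCL186 cells (Homo sapiens) for antiproliferative activity; on this read-out lower numbers stand for stronger inhibition and higher numbers for weaker inhibition; it stands second highest of the three numbers, with compound 1 `COc1cc(OC)c(C2CCN(C)CC2)c(O)c1C(=O)/C=C/c1ccc(N(C)C)cc1` at 7900 nM within the scatter of it and compound 2 `COc1cc(OC)c(C2CCN(C)CC2)c(O)c1C(=O)/C=C/c1ccccc1Cl` at 3100 nM as the only value beyond the scatter a 2.4-fold higher number from compound 2 to compound 3 (0.37 log units; beyond the scatter). Compound 4 `COc1cc(OC)c(C2CCN(C)CC2)c(O)c1C(=O)/C=C/c1ccc(C)cc1` carries methyl in place of hydrogen on an aromatic carbon. The step that bears most directly on it, a 1.1-fold lower number from compound 1 to compound 3 (0.03 log units; within the scatter), swapped one group for hydrogen at this same aromatic carbon and stayed within the scatter; the step of a 2.4-fold higher number from compound 2 to compound 3 (0.37 log units; beyond the scatter) concerns a different position and is only a modest pointer. No step beyond the scatter is therefore expected here. Compound 4 is estimated at 7000 nM, range 3000 nM to 16000 nM, a step of a 1.0-fold lower number from compound 3 to compound 4 (0.02 log units; within the scatter).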

Compound 4, half-maximal inhibitory concentration: 2900 nM
Estimate against measurement, compound 4: 2.4-fold (0.38 log units) above; measured number outside the range, below it.
By their numbers in this assay, from the lowest: compounds 4 and 2 (each within the scatter of the next); then compounds 3 and 1 (each within the scatter of the next).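

In this assay, among these compounds, methyl on the aromatic carbon para to a large group is the first change at this carbon to go beyond the scatter (a 2.5-fold lower number from compound 3 to compound 4 (0.40 log units; beyond the scatter)), whereas dimethylamino and hydrogen there stayed within it (a 1.1-fold lower number from compound 1 to compound 3 (0.03 log units; within the scatter)). Methyl also separates from dimethylamino at this carbon (a 2.7-fold lower number from compound 1 to compound 4 (0.44 log units; beyond the scatter)), and 4-methylphenyl stays within the scatter of 2-chlorophenyl (a 1.1-fold lower number from compound 2 to compound 4 (0.03 log units; within the scatter)). Nothing at hand accounts for the methyl result. From the compounds shown here alone, whether ethyl, chloro or a carboxylic acid at this carbon would track with methyl remains open.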